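Allyl series: swap of the halogenated aryl group

This account rests on a few compounds, and the source may have more. Where it says the series, first, only, none or still open, it means among the compounds named here.

Compound 1 `C=CCn1c(=O)/c(=C\c2ccc(F)c(Br)c2)[nH]c(=O)/c1=C\c1ccccc1OC` is reported in a functional assay on HL-60 cells (Homo sapiens) for cytotoxicity, read by CCK-8 assay, with a stated time of 72 h (a lower number here means a stronger inhibitor, a higher number a weaker inhibitor), as "not active" (no number reported), a result given without a number, so it offers no fixed point from which a step can be measured. Among the compounds with values here, compound 2 `COc1ccccc1/C=c1/[nH]c(=O)/c(=C\c2ccccc2OC)n(C)c1=O`, the only member with a numeric result, gives in this assay 16200 nM, a weak value that sets the only scale available here. Compound 3 `C=CCn1c(=O)/c(=C\c2ccccc2Cl)[nH]c(=O)/c1=C\c1ccccc1OC` differs from compound 1 by a single exchange: 2-chlorophenyl in place of 3-bromo-4-fluorophenyl on a double-bonded chain carbon bound to an aromatic carbon. Within the data shown here, no step between measured compounds exists, so no direction can be read off; the expectation is a small shift at most, likely none beyond the scatter. The weak range is anchored because compound 2 gives 16200 nM in this assay, and compound 1 without a number points the same way. Compound 3 is therefore expected to give in this assay about 25000 nM, within an estimated range from 8000 nM to 80000 nM, with a fair chance that only an inactive result is reported.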

Compound 3, half-maximal inhibitory concentration: 4200 nM
Estimate against measurement, compound 3: 6.0-fold (0.77 log units) above, outside the stated range (below it).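

Compound 3 has a number in this assay and compound 1 has none, so no step can be read between them. Going by these compounds, whether exchanging 3-bromo-4-fluorophenyl for 2-chlorophenyl changes the read-out, and by how much, stays open. No supporting evidence bears on this result.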